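The source may report more compounds than this note shows. Statements on the series, on what has been measured and on what is new or still open speak of the compounds shown alone.

Measured so far in a functional assay on cells (Cancer cell lines, Homo sapiens) for cytotoxicity, read by sulforhodamine B assay, with a stated time of 48 h; on this read-out lower numbers stand for stronger inhibition of growth and higher numbers for weaker inhibition of growth:
- compound 1 `COc1ccc(OC)c(-c2cc(-c3ccccc3)nn2-c2ccc(S(N)(=O)=O)cc2)c1` gives 13600 nM
- compound 2 `COc1ccc(OC)c(-c2cc(-c3ccccc3)nn2-c2ccc(S(=O)(=O)NC(C)=O)cc2)c1` gives 13300 nM
- compound 3 `COc1ccc(OC)c(-c2cc(-c3ccc(Cl)cc3)nn2-c2ccc(S(=O)(=O)NC(C)=O)cc2)c1` gives 23400 nM

Among these, compound 2 shows the lowest number, yet its separation from compound 1 a 1.0-fold lower number from compound 1 to compound 2 (0.01 log units; within the scatter) and from compound 3 a 1.8-fold higher number from compound 2 to compound 3 (0.25 log units; within the scatter) both fall within the scatter of this assay, so no ordering among the three can be claimed.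

Compound 4 `CC(=O)NS(=O)(=O)c1ccc(-n2nc(-c3ccccc3)cc2-c2cc(O)ccc2O)cc1` is reached from compound 2 by a single change: 2,5-dihydroxyphenyl in place of 2,5-dimethoxyphenyl on an aromatic carbon. Neither measured step touches this part of the molecule; one changes the group on the sulfonamide nitrogen, the other the phenyl on the far side of the shared core, and both stayed within the scatter. There is therefore no direct evidence on which to expect a sizeable move in this assay in either direction, and the working expectation is a number close to that of compound 2. Compound 4 is accordingly estimated at 12000 nM, within a range of 4000 nM to 40000 nM, which corresponds to an expected step of a 1.1-fold lower number from compound 2 to compound 4 (0.04 log units; within the scatter).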

Compound 4, concentration for 50% growth inhibition: 100000 nM
The estimate for compound 4 lay 8.3-fold (0.92 log units) below the measured number; the whole stated range lies below it.
By their numbers in this assay, from the lowest: compounds 2, 1 and 3 (each within the scatter of the next); then compound 4.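

In this assay, this is the only step shown that lies beyond the scatter: 2,5-dihydroxyphenyl in place of 2,5-dimethoxyphenyl gives a 7.5-fold higher number from compound 2 to compound 4 (0.88 log units; beyond the scatter), whereas the changes on the sulfonamide nitrogen and on the phenyl at the far side of the core did not. The number at this position therefore depends on what the aromatic ring carries, and here the swap from the two methoxy groups to the two hydroxyl groups weakens growth inhibition. No measurement available here explains this rise.

On these data alone, it remains open whether both methoxy groups are needed, which a ring carrying one methoxy and one hydroxyl could test. Ethoxy or amino groups in the same places could show whether the effect is specific to hydroxyl.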